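The compounds below may be only part of what the source reports. "The series", "measured", "known", "first", "only" and "open" are said of these compounds alone.

Of the compounds shown here, three built on one shared core have been tested in a functional assay on NCI/ADR-RES cells (Homo sapiens) for cytotoxicity, read by sulforhodamine B assay, with a stated time of 48 h, tested at 1 uM; on this read-out lower numbers stand for a stronger effect and higher numbers for a weaker effect at the one concentration tested. Compound 1 `COc1cc(-c2cc(/C=C/C(=O)c3ccc(N)cc3)[nH]n2)cc(OC)c1OC` gives 98% in this assay. Compound 2 `COc1cc(-c2cc(/C=C/C(=O)c3ccc(Cl)c(Cl)c3)[nH]n2)cc(OC)c1OC` gives 92%. Compound 3 `COc1ccc(C(=O)/C=C/c2cc(-c3cc(OC)c(OC)c(OC)c3)n[nH]2)cc1` gives 90%. Compound 3 carries the lowest of the three numbers, but its gaps to the other two are within the usual scatter, so the three readings cannot be told apart. The steps among them, a number 6 percentage points lower from compound 1 to compound 2 (within the scatter), a number 2 percentage points lower from compound 2 to compound 3 (within the scatter) and a number 8 percentage points lower from compound 1 to compound 3 (within the scatter), all stay within the scatter as well.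

Compound 4 `COc1cc(-c2cc(/C=C/C(=O)c3ccc(F)c(F)c3)[nH]n2)cc(OC)c1OC` has not yet been measured. It differs from compound 3 in one place: 3,4-difluorophenyl in place of 4-methoxyphenyl on a carbonyl carbon. Among the measured compounds shown here, the steps that bear on this change are the two that already swap the ring on the carbonyl carbon, a number 6 percentage points lower from compound 1 to compound 2 (within the scatter) and a number 2 percentage points lower from compound 2 to compound 3 (within the scatter); both were small and within the scatter, and three different rings at that position gave much the same reading. A further swap at the same position is therefore expected to move the number little, if at all. For compound 4 the expected step is a number 2 percentage points higher from compound 3 to compound 4 (within the scatter), within the scatter. Compound 4 is estimated to give 92%, with a likely range from 82% to 100%.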

Compound 4, a percentage reported as activity, at one concentration (the size of the read-out at that concentration, not a potency): 95%
The estimate for compound 4 lay 3 percentage points below the measured number; measured number inside the range.
By their numbers in this assay, from the lowest: compounds 3, 2, 4 and 1 (each within the scatter of the next).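

With 3,4-difluorophenyl, a fourth ring on the carbonyl carbon has been read in this assay, and it cannot be told apart from the other three: a number 5 percentage points higher from compound 3 to compound 4 (within the scatter), a number 3 percentage points higher from compound 2 to compound 4 (within the scatter) and a number 3 percentage points lower from compound 1 to compound 4 (within the scatter). Among the compounds shown here, the second of these steps is a kind of change the earlier compounds did not include, since both chlorine atoms are exchanged for fluorine atoms while the ring otherwise stays the same, and the first shows that replacing 4-methoxyphenyl, which counts one hydrogen-bond acceptor, with a ring that counts none also leaves the reading within the scatter. Nothing measured here offers an explanation for how closely these readings sit together.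

The four compounds vary only this one ring, and every ring shown is a six-membered aromatic ring of carbon only, so a non-aromatic ring such as cyclohexyl, or a carboxylic acid on the aromatic ring, remains an open case at this position. Going by these compounds, whether the four rings would separate at any other concentration also stays open, as does the effect of any change elsewhere on the shared core.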